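Trading a Sulfoxide for a Thioether at the Anilino Ring

The source may report more compounds than this note shows. Statements on the series, on what has been measured and on what is new or still open speak of the compounds shown alone.

In a functional assay on NCI-H2228 cells (Homo sapiens) for inhibition, read by CCK-8 assay (a higher number here means a weaker inhibitor, a lower number a stronger inhibitor), compound 1 `CC[S+]([O-])c1ccccc1Nc1nc(Nc2ccc(N3CCN(C)CC3)cc2OC)ncc1Cl` gives 35.2 nM. Compound 3 `CC[S+]([O-])c1ccccc1Nc1nc(Nc2ccc(N(C)CCN(C)C)cc2OC)ncc1Cl` gives 69.3 nM, and the step of a 2.0-fold higher number from compound 1 to compound 3 (0.29 log units; within the scatter) stays within the scatter. Compound 2 `CC[S+]([O-])c1cc(F)ccc1Nc1nc(Nc2ccc(N3CCC(N(C)C)CC3)cc2OC)ncc1Cl` gives 337 nM, a number beyond the scatter from compound 1. Compound 4 `CCSc1ccccc1Nc1nc(Nc2ccc(N3CCN(C)CC3)cc2OC)ncc1Cl` differs from compound 1 only at the aromatic ring that carries the ethylsulfinyl group: a group of 3 heavy atoms (2 carbon, 1 sulfur; no ring) in place of a group of 4 heavy atoms (2 carbon, 1 oxygen, 1 sulfur; no ring), on an aromatic carbon. Within the data shown here, no measured step touches this position; the single step recorded, from compound 1 to compound 3, changes a group on the other aromatic ring and lies within the scatter. Nothing here points to a change beyond the scatter in this assay. Compound 4 is therefore estimated at 50 nM, with a range from 15 nM to 170 nM. This estimate means a step of a 1.4-fold higher number from compound 1 to compound 4 (0.15 log units; within the scatter).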

Compound 4, half-maximal inhibitory concentration: 981 nM
The estimate for compound 4 lay 20-fold (1.29 log units) below the measured number; the whole stated range lies below it.
By their numbers in this assay, from the lowest: compounds 1 and 3 (each within the scatter of the next); then compound 2; then compound 4.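

In this assay, taking away the one oxygen atom of the ethylsulfinyl group to leave ethylsulfanyl gives a 28-fold higher number from compound 1 to compound 4 (1.45 log units; beyond the scatter). Among these compounds, this is the first sign that the group on this ring strongly affects the number, and even a change of a single atom counts here. The data offer no explanation for the size of this step. Still open, going by these compounds, is whether a sulfone, with two oxygen atoms on the sulfur, would match compound 1. It is also unclear whether the same loss would appear with the side chain of compound 3.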